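This account rests on a few compounds, and the source may have more. Where it says the series, first, only, none or still open, it means among the compounds named here.

In a toxicity assay on mitochondria from liver (Rattus norvegicus) for inhibition, in the presence of a further agent that is not named here (a higher number here means a weaker inhibitor, a lower number a stronger inhibitor), compound 1 (`Cc1c(C)n(C(=O)c2ccc(O)c(C#N)c2)c2ccccc12`) gives 3600 nM and compound 2 (`CC(C)(C)c1cc(C(=O)N2CCc3ccccc32)cc(C#N)c1O`) gives 6600 nM. Compound 3 (`N#Cc1cc(C(=O)N2CS(=O)(=O)c3ccccc32)cc(C2CC2)c1O`) gives 59000 nM, the highest of the three numbers and beyond the scatter from both others. Compound 4 (`CCc1cc(C(=O)N2CS(=O)(=O)c3ccccc32)cc(C#N)c1O`) has ethyl in place of cyclopropyl on an aromatic carbon, ortho to a hydroxy group and meta to a cyano group: ethyl in place of cyclopropyl on an aromatic carbon. Among the compounds with values here, no two measured compounds differ in one place, so the series offers no direct guide to this change. In this assay, no step beyond the scatter is expected. The estimate is a small step of a 1.2-fold lower number from compound 3 to compound 4 (0.07 log units; within the scatter), within the scatter. The expected value for compound 4 is 50000 nM, with an estimated range of 20000 nM to 120000 nM.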

Compound 4, half-maximal inhibitory concentration: 37000 nM
Compound 4: the middle estimate sits 1.4-fold (0.13 log units) above what was measured; the range from low to high includes it.
By their numbers in this assay, from the lowest: compounds 1 and 2 (each within the scatter of the next); then compounds 4 and 3 (each within the scatter of the next).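

This pair gives the series its first single-place comparison: in this assay, ethyl in place of cyclopropyl on an aromatic carbon, ortho to a hydroxy group and meta to a cyano group, gives a 1.6-fold lower number from compound 3 to compound 4 (0.20 log units; within the scatter) and stays within the scatter. At this position, on this core, the three-membered ring can therefore be opened and one carbon lost without a step beyond the scatter. No measurement bears on why the two groups read alike.

As far as these compounds go, whether an amine, a carboxylic acid or a longer chain at this position would stay within the scatter remains open. So does whether the same change would read alike on the cores of compound 1 and compound 2.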